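Series notes: removing the hexyloxy chain from compound 1

The compounds below may be only part of what the source reports. "The series", "measured", "known", "first", "only" and "open" are said of these compounds alone.

Compound 1 `CCCCCCOc1ccccc1-c1nnc(CNC)s1` is one of two compounds of this series with a number in a functional assay on the whole organism with Mus musculus as the target; on this read-out higher numbers stand for an effect only at larger amounts of compound and lower numbers for an effect already at smaller amounts; in this assay compound 1 gives 44 mg/kg. Compound 2 `CC(C)NCc1nnc(-c2ccccc2-c2ccccc2)s1` is the other measured member, and in this assay compound 2 gives 23 mg/kg. Compound 1 stands with the highest of the two numbers, but the gap to compound 2 is within the usual scatter, so the two values show no order between them.

Compound 3 `CNCc1nnc(-c2ccccc2)s1` has not yet been measured in this assay. The change from compound 1 to compound 3 is hydrogen in place of hexyloxy on an aromatic carbon. Going by the values given here, no measured pair follows this kind of change, so no step size is known for it. The two measured compounds, which differ in several places at once, sit within the scatter of each other, and this gives no guide to the direction.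

The step in this assay from compound 1 to compound 3 is expected to be a 1.5-fold higher number from compound 1 to compound 3 (0.17 log units; within the scatter), towards a somewhat higher number, with a wide range. For compound 3 the estimated value in this assay is 65 mg/kg, between 25 mg/kg and 170 mg/kg.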

Compound 3, dose for half-maximal effect: > 200 mg/kg
Compound 3: a limit, no number; the forecaster's own chance of this, stated with the estimate: 10%; middle value at least 3.0-fold (0.48 log units) from the limit.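

Going by these compounds alone, the position carrying hexyloxy now has a first step of its own: with hydrogen in place of hexyloxy on the aromatic carbon, this assay gives an at least 4.5-fold higher number from compound 1 to compound 3 (0.65 log units; beyond the scatter). Within the data shown here, this is the first gap that lies beyond the scatter, and it comes from a change in one place, which compound 1 and compound 2 could not offer as a pair, since they differ in several places at once. The result for compound 3 is a limit and not a number, so the step has a known minimum while its full size stays open: the limit of > 200 mg/kg in this assay, at which 1 of the 3 values shown sits.

The compounds shown leave open whether a short ether such as methoxy or ethoxy on the same aromatic carbon would keep the number close to that of compound 1, and whether a longer chain such as octyloxy would shift it in either direction. They also leave open whether the same change gives a step of similar size with another amine on the other side of the core, such as the isopropylamine of compound 2, which differs from compound 3 in more than one place.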